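A few compounds are considered here, and "the series" means these few. Any claim that something is new, unique, unknown or untested is made for them only; others in the source may bear on it.

Measured in a functional assay on A2780 cells (Homo sapiens) for antiproliferative activity, read by MTT assay, with a stated time of 48 h; a lower number here means a stronger inhibitor, a higher number a weaker inhibitor:
- compound 1 `COc1ccc(C(=O)c2ccc(OC)c3c2C=CC(C)(C)O3)c(NC(=O)CO)c1` gives 420 nM
- compound 2 `CNCC(=O)Nc1cc(OC)ccc1C(=O)c1ccc(OC)c2c1OC(C)(C)C=C2` gives 620 nM

Compound 1, at 420 nM, is one of only two measured points. Its value and that of compound 2, at 620 nM, lie within the usual scatter of each other, so this assay does not separate the two compounds.

Next in the series is compound 3 `COc1ccc(C(=O)c2ccc(OC)c3c2C=CC(C)(C)O3)c(NC(=O)CN(C)C)c1`, not yet measured. Going from compound 1 to compound 3 puts dimethylamino in place of hydroxy on a saturated chain carbon bound to a carbonyl carbon.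

Among the compounds with values here, no measured step between two compounds shows what a single change of this kind does here, so the expectation rests on only two values. With compound 1 at 420 nM and compound 2 at 620 nM, the working expectation is a number in the same region, with no step beyond the scatter and a slight lean towards a higher number. The expected change is a 1.4-fold higher number from compound 1 to compound 3 (0.15 log units; within the scatter). For compound 3 the estimated value is 600 nM, with an expected range of 200 nM to 1800 nM.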

Compound 3, half-maximal inhibitory concentration: 3990 nM
Beside the measured number, compound 3's estimate is 6.7-fold (0.82 log units) below it, outside the stated range (above it).
By their numbers in this assay, from the lowest: compounds 1 and 2 (each within the scatter of the next); then compound 3.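

Putting dimethylamino in place of hydroxy on a saturated chain carbon bound to a carbonyl carbon gives a 9.5-fold higher number from compound 1 to compound 3 (0.98 log units; beyond the scatter) in this assay, a step beyond the usual scatter. Within the data shown here, this is the first single-change step, and it shows that the number in this assay responds to what this chain carbon carries, something the two earlier values could not show, since they lie within the scatter of each other and are not linked by a single change. Nothing at hand bears on the reason for this step, so the result stands here as an observation only.

Among these compounds, the single step does not tell whether the higher number follows from the loss of hydroxy or from the arrival of dimethylamino, and a methoxy group or an unsubstituted amino group on the same carbon would help to separate the two readings. Going by these compounds, it also remains open how far the change carries over to larger groups at this place, such as a morpholine ring or a longer chain ending in hydroxy, and whether any group here gives a lower number than hydroxy does.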